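The compounds below may be only part of what the source reports. "The series", "measured", "known", "first", "only" and "open" are said of these compounds alone.

Measured compounds:
- compound 1 `CCC(=O)Nc1ccc(-c2nc3cc(C(F)(F)F)ccc3n2C2CCCCC2)cc1`, in an ADME assay on Vero cells (Chlorocebus sabaeus) for cytotoxicity (a lower number here means that less compound is tolerated, a higher number that more compound is tolerated), compound 1 gives > 100000 nM
- compound 2 `O=C(CN1CCCCC1)Nc1ccc(-c2nc3cc(Cl)c(Cl)cc3[nH]2)cc1`, for which compound 2 gives > 100000 nM
- compound 3 `CCN(CC)CC(=O)Nc1ccc(-c2nc3cc(C(F)(F)F)ccc3[nH]2)cc1`, for which compound 3 gives 24000 nM

The value for compound 1 is a limit of the assay, not a number. The value for compound 2 is also a limit. Only compound 3 returns a measured number. So compound 1 cannot be placed on a scale among these three; it sits at the limit of > 100000 nM in this assay, at which 2 of the 3 values shown sit, and the single numeric value, that of compound 3, lies well inside the range the assay can report.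

Compound 4 `CCC(=O)Nc1ccc(-c2nc3cc(C(F)(F)F)ccc3n2C)cc1` differs from compound 1 in one place: methyl in place of cyclohexyl on an aromatic nitrogen. Among the compounds with values here, no pair of measured compounds differing in just one place is available here, so the size of this step has no measured precedent. Given that compound 1 already sits at the limit, the most likely outcome is that compound 4 also returns a limit, and any real change is expected to be none beyond the usual scatter. The step from compound 1 to compound 4 is estimated as a number no higher from compound 1 to compound 4 (the limit leaves the size open). Compound 4 is expected to give about 100000 nM, within a range of 40000 nM to 300000 nM.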

Compound 4, half-maximal cytotoxic concentration: > 100000 nM
Compound 4 ended at the assay's limit; the forecaster's own chance of this, stated with the estimate: 70%; the middle value lies on the limit itself.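

In this assay compound 4 gives > 100000 nM, which is a limit of the assay and not a number. Within the data shown here, compound 1 also gives a limit, so no step from compound 1 to compound 4 can be read. The compounds shown leave open whether methyl and cyclohexyl on the aromatic nitrogen differ at all in how much compound is tolerated, as both compounds stand at the same point: the limit of > 100000 nM in this assay, at which 3 of the 4 values shown sit.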